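Ring-carbon substituent removal on the shared core

The source may hold more compounds than are shown below. What is called first, only, known or untested is meant among the compounds shown, and "the series" means these compounds.

Measured so far in an assay on isolated protein for inhibition of serine/threonine-protein kinase PLK1 (Homo sapiens), read by Z'-LYTE; a higher number here means a weaker inhibitor, a lower number a stronger inhibitor:
compound 1 `CC[C@@H]1C(=O)Nc2cnc(Nc3ccc(C(=O)NC4CCN(C)CC4)cc3OC)nc2N1C1CCCCC1` gives 37.2 nM
compound 2 `COc1cc(C(=O)NC2CCN(C)CC2)ccc1Nc1ncc2c(n1)N(C1CCCC1)[C@H](C)C(=O)N2C` gives 1.1 nM
compound 3 `CCC[C@@H]1C(=O)N(C)c2cnc(Nc3ccc(C(=O)NC4CCN(C)CC4)cc3OC)nc2N1C1CCCC1` gives 9.9 nM

Compound 3 stands second highest of the three numbers; its nearest neighbour is compound 1 and its furthest is compound 2. The change now considered is hydrogen in place of propyl on a saturated ring carbon, giving compound 4 `COc1cc(C(=O)NC2CCN(C)CC2)ccc1Nc1ncc2c(n1)N(C1CCCC1)CC(=O)N2C`, which is not yet measured.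

Going by the values given here, one measured step bears on this change: a 9.0-fold higher number from compound 2 to compound 3 (0.95 log units; beyond the scatter), in which the substituent on that ring carbon was lengthened and the number rose well beyond the scatter. Compound 4 goes the other way, with the substituent removed altogether. Among the compounds with values here, compound 1 offers no direct step to compound 3, since it differs from it in more than one place; its value only shows that a different combination of groups on the same core sits well above compound 2. Within the data shown here, on this basis a step downward from compound 3 is expected, of a size comparable to the step already seen, though there is no measured compound without any group at this ring carbon to anchor it, so the range is kept wide. Compound 4 is therefore estimated at 3 nM (range 0.8 nM to 12 nM), meaning an expected step of a 3.3-fold lower number from compound 3 to compound 4 (0.52 log units; beyond the scatter).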

Compound 4, half-maximal inhibitory concentration: 54.1 nM
Compound 4: the middle estimate sits 18-fold (1.26 log units) below what was measured; the whole stated range lies below it.
By their numbers in this assay, from the lowest: compound 2; then compound 3; then compounds 1 and 4 (each within the scatter of the next).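

In this assay, taking propyl off the saturated ring carbon does not lower the number but raises it, a 5.5-fold higher number from compound 3 to compound 4 (0.74 log units; beyond the scatter), so a hydrogen at this carbon gives a weaker inhibitor than propyl does. The loss is far larger when hydrogen replaces methyl, a 49-fold higher number from compound 2 to compound 4 (1.69 log units; beyond the scatter); read with a 9.0-fold higher number from compound 2 to compound 3 (0.95 log units; beyond the scatter), the order at this carbon runs from methyl as the strongest, through propyl, to hydrogen as the weakest, so the number does not follow substituent size in one direction across these three compounds. Nothing available explains this order.

Ethyl on this ring carbon, with the cyclopentyl group and the ring-nitrogen methyl group of compound 2 kept, remains open, as does a branched group such as isopropyl, so the shape of the response between methyl and propyl is not fixed by the compounds shown. Also open, from the compounds shown here alone, are a second methyl on the same carbon and a hydroxymethyl group, as well as the opposite stereochemistry of the methyl group in compound 2.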